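Swapping the substituent on the ring amine nitrogen

A few compounds are considered here, and "the series" means these few. Any claim that something is new, unique, unknown or untested is made for them only; others in the source may bear on it.

Measured so far:
compound 1 `CCN(CC)c1ccc2cc(C(=O)c3ccc(N4CCN(C(=O)CN5CCN(C(=O)CCl)CC5)CC4)cc3)oc2c1` — 20900 nM
compound 2 `CCN(CC)c1ccc2cc(C(=O)c3ccc(N4CCN(C(=O)CN5CCN(S(=O)(=O)c6ccc(C#N)cc6)CC5)CC4)cc3)oc2c1` — 44100 nM

Both were run in an ADME assay on L02 cells (Homo sapiens) for cytotoxicity, read by MTT assay, with a stated time of 48 h; on this read-out higher numbers stand for weaker inhibition and lower numbers for stronger inhibition. Compound 2 stands highest of the two numbers; its nearest neighbour is compound 1, and the step of a 2.1-fold higher number from compound 1 to compound 2 (0.32 log units; beyond the scatter) is beyond the scatter but modest. Compound 3 `CCN(CC)c1ccc2cc(C(=O)c3ccc(N4CCN(C(=O)CN5CCN(CC(C)=O)CC5)CC4)cc3)oc2c1` is not yet measured. It differs from compound 2 by 2-oxopropyl in place of (4-cyanophenyl)sulfonyl on an amine nitrogen in a ring. For the measured compounds named here, the one measured step bearing on this position is a 2.1-fold higher number from compound 1 to compound 2 (0.32 log units; beyond the scatter): exchanging the group on the same ring nitrogen moved the number only modestly, so a move of similar or smaller size is the most that the two numbers support. The 2-oxopropyl group carries fewer heavy atoms than the group it replaces, and no large move is expected. The step of a 1.6-fold lower number from compound 2 to compound 3 (0.20 log units; within the scatter) is expected to stay near the scatter. For compound 3 the estimate is 28000 nM, with a range from 12000 nM to 65000 nM.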

Compound 3, half-maximal inhibitory concentration: > 100000 nM
Compound 3 ended at the assay's limit; the forecaster's own chance of this, stated with the estimate: 15%; middle value at least 3.5-fold (0.55 log units) from the limit.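

In this assay the reading for compound 3 is a limit of the assay and not a number: the limit of > 100000 nM in this assay, at which 1 of the 3 values shown sits. The group on this ring nitrogen can therefore shift the read-out by more than the modest first exchange suggested, with an at least 2.2-fold higher number from compound 2 to compound 3 (0.35 log units; beyond the scatter) and an at least 4.7-fold higher number from compound 1 to compound 3 (0.67 log units; beyond the scatter). Compound 3 is also the only one of the three in which the ring nitrogen bears a carbon that is not part of a carbonyl, though a single compound cannot tie the steps to that feature.

As far as these compounds go, the full size of both steps stays unknown, since only their lower bounds can be read. Also open, from the compounds shown here alone, is whether a longer alkyl chain or a free amine on this ring nitrogen would read like compound 3 or like compound 1 and compound 2.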